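The source may hold more compounds than are shown below. What is called first, only, known or untested is meant among the compounds shown, and "the series" means these compounds.

In a functional assay on A549 cells (Homo sapiens) for cytotoxicity, read by MTT assay, with a stated time of 72 h (a higher number here means a weaker inhibitor, a lower number a stronger inhibitor), compound 3 (`CNC(=O)c1cc(Oc2ccc(C(=O)/C=C/c3ccccc3)cc2)ccn1`) gives 5040 nM with its unsubstituted phenyl. Compound 1 (`CNC(=O)c1cc(Oc2ccc(C(=O)/C=C/c3cccc(Br)c3)cc2)ccn1`) gives 9940 nM with a 3-bromophenyl, and a 2.0-fold lower number from compound 1 to compound 3 (0.29 log units; within the scatter) leaves these two unranked. Compound 2 (`CNC(=O)c1cc(Oc2ccc(C(=O)/C=C/c3ccc(C#N)cc3)cc2)ccn1`) gives 26400 nM with a 4-cyanophenyl, so compound 3 stands clear of compound 2 but not of compound 1. The gap between the two substituted compounds is a 2.7-fold higher number from compound 1 to compound 2 (0.42 log units; beyond the scatter) and is a real one.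

The next entry is compound 4 (`CNC(=O)c1cc(Oc2ccc(C(=O)/C=C/c3ccc(F)cc3)cc2)ccn1`), with the change fluoro in place of hydrogen on an aromatic carbon in which fluoro takes the place of hydrogen on an aromatic carbon, para to a large group. For the measured compounds named here, the nearest precedent is the cyano compound, substituted at that same place, where a 5.2-fold lower number from compound 2 to compound 3 (0.72 log units; beyond the scatter) marks a modest step. The bromo step a 2.0-fold lower number from compound 1 to compound 3 (0.29 log units; within the scatter) is a weaker guide, being at another place on the ring. Going by the values given here, no fluoro compound has been measured yet.

A small move toward a higher number in this assay is expected, probably within the scatter, and the estimate is a 1.4-fold higher number from compound 3 to compound 4 (0.14 log units; within the scatter) as the likely step. Compound 4 is estimated at 7000 nM with an expected range of 3000 nM to 16000 nM in this series.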

Compound 4, half-maximal inhibitory concentration: 18600 nM
Estimate against measurement, compound 4: 2.7-fold (0.42 log units) below; measured number above the stated range.
By their numbers in this assay, from the lowest: compounds 3, 1, 4 and 2 (each within the scatter of the next, the first and the last beyond it).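

In this assay, a group of a single heavy atom is enough to matter at this place: with fluoro on the aromatic carbon para to a large group, the step is a 3.7-fold higher number from compound 3 to compound 4 (0.57 log units; beyond the scatter). Fluoro and cyano at this place cannot be told apart, at a 1.4-fold lower number from compound 2 to compound 4 (0.15 log units; within the scatter), so both compounds sit clear of the unsubstituted phenyl of compound 3, and the 3-bromophenyl compound is not separated from the fluoro compound either, at a 1.9-fold higher number from compound 1 to compound 4 (0.27 log units; within the scatter). Nothing measured on these compounds bears on what lies behind the fluoro step.

Still open, from the compounds shown here alone, is whether any group at this place raises the number or only these two do, which a methoxy group, an amine or a carboxylic acid there would test. Also open, going by these compounds, is how fluoro behaves elsewhere on the ring, as in the 3-fluorophenyl analogue of compound 1.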